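Compound 3 to compound 4: pyridin-2-yl exchange

The source may hold more compounds than are shown below. What is called first, only, known or untested is meant among the compounds shown, and "the series" means these compounds.

Values measured in a functional assay on MGC-803 cells (Homo sapiens) for antiproliferative activity, read by MTT assay, with a stated time of 72 h (on this read-out lower numbers stand for stronger inhibition and higher numbers for weaker inhibition), are:
compound 1 `C/C(=N\NC(=O)c1cccc(S(=O)(=O)N2CCOCC2)c1)c1ccccc1O` at 1220 nM
compound 2 `C/C(=N\NC(=O)c1cccc(S(=O)(=O)N2CCOCC2)c1)c1cc(Br)ccc1O` at 18000 nM
compound 3 `O=C(N/N=C/c1ccccn1)c1cccc(S(=O)(=O)N2CCOCC2)c1` at 81700 nM

Compound 3 has the highest number of the three, beyond the scatter from both compound 1 and compound 2. Among the measured compounds shown here, the next structure is compound 4 `O=C(N/N=C/c1cc(Br)ccc1O)c1cccc(S(=O)(=O)N2CCOCC2)c1` with the difference 5-bromo-2-hydroxyphenyl in place of pyridin-2-yl on a carbon with a double bond to nitrogen as its only change. In words, this is 5-bromo-2-hydroxyphenyl in place of pyridin-2-yl on a carbon with a double bond to nitrogen.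

For the measured compounds named here, no measured step covers this exchange directly. Going by the values given here, the only step available is a 15-fold higher number from compound 1 to compound 2 (1.17 log units; beyond the scatter) for bromo in place of hydrogen on an aromatic carbon, a large rise that warns against treating the bromo group as favourable. The nearest guide is compound 2, which carries the entering 5-bromo-2-hydroxyphenyl group and gives 18000 nM in this assay as a number still lower than that of compound 3. A fall in the number beyond the scatter is therefore expected, landing near compound 2 rather than compound 1. The expected change is a 5.4-fold lower number from compound 3 to compound 4 (0.74 log units; beyond the scatter) on this estimate. Compound 4 is estimated at 15000 nM with an expected span from 3000 nM to 50000 nM as the working range.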

Compound 4, half-maximal inhibitory concentration: 14800 nM
Estimate against measurement, compound 4: 1.0-fold (0.01 log units) above; the range from low to high includes it.
By their numbers in this assay, from the lowest: compound 1; then compounds 4 and 2 (each within the scatter of the next); then compound 3.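

In this assay, the exchange on a carbon with a double bond to nitrogen gives a 5.5-fold lower number from compound 3 to compound 4 (0.74 log units; beyond the scatter), so the number responds to the group at this place, and a 5-bromo-2-hydroxyphenyl group there is compatible with a number lower than that of the pyridin-2-yl compound. Among the compounds shown here, the bromo-bearing compounds now number two, with compound 2 at 18000 nM and compound 4 at 14800 nM, and these two values lie within the scatter of each other, although the only bromo step, a 15-fold higher number from compound 1 to compound 2 (1.17 log units; beyond the scatter), is a rise beyond the scatter. The exchange replaces the ring, the hydroxy and the bromo in one move, so this step cannot be divided among them, and no measured information on the cause is available.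

The compounds shown leave open how much of the fall belongs to the hydroxy and how much to the bromo, and whether the bromo step seen with compound 1 and compound 2 would hold on the carbon that lacks a methyl group. Also open, on these data alone, is what a methoxy group or an amine would give in place of the hydroxy at this place.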